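The compounds below may be only part of what the source reports. "The series", "measured", "known", "first", "only" and "open" are said of these compounds alone.

Three compounds share one core and differ only in the group carried by the amide nitrogen. Compound 1 `CC(C)[C@H](C(=O)Nc1ccccc1)c1ccc(Cl)cc1` bears a phenyl there. In a functional assay on CHO cells for agonist activity at Free fatty acid receptor 2 (Homo sapiens), read by cAMP accumulation (on this read-out higher numbers stand for larger maximal responses and lower numbers for smaller maximal responses), compound 1 reaches < 30%, which is a limit of the assay rather than a measured number, and this is the limit of < 30% in this assay, at which 1 of the 3 values shown sits. Compound 2 `CC(C)C(C(=O)Nc1ncccn1)c1ccc(Cl)cc1` gives 50% in this assay, and compound 3 `CC(C)[C@H](C(=O)Nc1nnc(C(F)(F)F)s1)c1ccc(Cl)cc1` gives 115%. Compound 4 `CC(C)[C@H](C(=O)Nc1ccon1)c1ccc(Cl)cc1` has not yet been measured, and it differs from compound 1 by 1,2-oxazol-3-yl in place of phenyl on an amide-type nitrogen. Both measured compounds with a heteroaromatic ring in place of the phenyl gave larger maximal responses than compound 1, so in this assay an upward step well beyond the usual scatter is expected, namely a number at least 50 percentage points higher from compound 1 to compound 4 (beyond the scatter). Compound 4 is therefore estimated to reach about 80%, with a likely range from 40% to 115%.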

Compound 4, largest response reached (reported as efficacy), in percent of the reference or control that the assay uses: 90%
Compound 4: middle estimate off by 10 percentage points, on the low side; the range from low to high includes it.
By their numbers in this assay, from the lowest: compound 2; then compound 4; then compound 3. At a limit, below all of these: compound 1.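

Among the compounds shown here, this gives the first step at this position that can be read between two compounds differing in one place only. In this assay, 1,2-oxazol-3-yl in place of phenyl on the amide-type nitrogen gives a number at least 60 percentage points higher from compound 1 to compound 4 (beyond the scatter). Compound 1 stands at a limit and not at a number, so the true size of this step stays unknown: the limit of < 30% in this assay, at which 1 of the 4 values shown sits.

The compounds shown cannot separate the part played by the ring nitrogen from that of the ring oxygen. They also leave open whether a ring is needed at all, a question that a butyl chain on the same nitrogen could test.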